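The source may report more compounds than this note shows. Statements on the series, on what has been measured and on what is new or still open speak of the compounds shown alone.

Measured compounds in an ADME assay on cells (Hepatocyte, Homo sapiens) for pharmacokinetics; on this read-out lower numbers stand for slow clearance and higher numbers for fast clearance:
- compound 1 `COc1nc(C2=NOCC(c3ccc(C)cc3)N2)ccc1-n1cnc(C)c1`: 135 mL/min/kg
- compound 2 `COc1nc(C2=NOCC(c3ccc(C4CC4)cc3)N2)ccc1-n1cnc(C)c1`: 208 mL/min/kg
- compound 3 `COc1nc(C2=NOCC(c3ccc(Cl)c(C)c3)N2)ccc1-n1cnc(C)c1`: 70 mL/min/kg

Compound 3 gives the lowest of the three numbers in this assay. Its nearest neighbour is compound 1, with a 1.9-fold lower number from compound 1 to compound 3 (0.29 log units; within the scatter), a step that sits within the scatter; its furthest is compound 2, with a 3.0-fold lower number from compound 2 to compound 3 (0.47 log units; beyond the scatter), a modest step that does lie beyond the scatter.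

Compound 4 `COc1nc(C2=NOCC(c3ccc(C)c(Cl)c3)N2)ccc1-n1cnc(C)c1` is the next member. It differs from compound 3 by 3-chloro-4-methylphenyl in place of 4-chloro-3-methylphenyl on a saturated ring carbon. The same atoms are present, joined differently.

Going by the values given here, two measured steps touch this position on the saturated ring carbon: a 1.9-fold lower number from compound 1 to compound 3 (0.29 log units; within the scatter) and a 3.0-fold lower number from compound 2 to compound 3 (0.47 log units; beyond the scatter). Both replaced one aryl group by another; neither exchanged the positions of the same substituents. Among the compounds with values here, both steps are small to modest, and nothing among the measured compounds points to a direction for a swap of chloro and methyl. Within the data shown here, for compound 4 the expectation is therefore no step beyond the scatter, a 1.1-fold higher number from compound 3 to compound 4 (0.06 log units; within the scatter), since compound 3 gives 70 mL/min/kg in this assay and the reshuffled aryl group has no precedent here. Compound 4 is estimated at 80 mL/min/kg in this assay, with a range of 40 mL/min/kg to 160 mL/min/kg.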

Compound 4, clearance: 422 mL/min/kg
Estimate against measurement, compound 4: 5.3-fold (0.72 log units) below; the whole stated range lies below it.
By their numbers in this assay, from the lowest: compounds 3, 1 and 2 (each within the scatter of the next, the first and the last beyond it); then compound 4.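

At this position on the saturated ring carbon, the arrangement of the two substituents matters in this assay: 3-chloro-4-methylphenyl in place of 4-chloro-3-methylphenyl gives a 6.0-fold higher number from compound 3 to compound 4 (0.78 log units; beyond the scatter), with the atoms unchanged. Chloro in place of hydrogen on the 4-methylphenyl group gives a 3.1-fold higher number from compound 1 to compound 4 (0.49 log units; beyond the scatter), and the aryl change from the cyclopropyl compound gives a 2.0-fold higher number from compound 2 to compound 4 (0.31 log units; beyond the scatter), so the aryl groups measured so far do not order by substituent type alone. No measurement on hand accounts for the swap.

Open, on these data alone, is whether the step follows the chloro or the methyl placement, which a phenyl group carrying chloro alone would help to separate. Also open, as far as these compounds go, is whether a nitrile or a methoxy group in place of the chloro keeps the same dependence on arrangement.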